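Ethoxy to Methylsulfonyl: Estimating Compound 4

The source may hold more compounds than are shown below. What is called first, only, known or untested is meant among the compounds shown, and "the series" means these compounds.

In a functional assay for antagonist activity at P2X purinoceptor 7 (Homo sapiens), read by FLIPR and calcium flux (a lower number here means a stronger inhibitor, a higher number a weaker inhibitor), compound 3 `CCOc1ccccc1CNc1ncnn1-c1cccc(Cl)c1Cl` gives 45.7 nM, the second highest of three numbers, lying within the scatter of compound 1 `Clc1cccc(-n2ncnc2NCc2ccccc2)c1Cl` at 47.9 nM and clearly apart from compound 2 `Cc1ccccc1CNc1ncnn1-c1cccc(Cl)c1Cl` at 20.9 nM. Compound 4 `CS(=O)(=O)c1ccccc1CNc1ncnn1-c1cccc(Cl)c1Cl` differs from compound 3 in one place: methylsulfonyl in place of ethoxy on an aromatic carbon. The measured steps that touch this position were a 1.0-fold lower number from compound 1 to compound 3 (0.02 log units; within the scatter) and a 2.2-fold higher number from compound 2 to compound 3 (0.34 log units; beyond the scatter), so substitution at this carbon has so far shifted the number only modestly in either direction. For the measured compounds named here, no measured step involves a methylsulfonyl group, so the direction of this change is open. Compound 4 is therefore expected to show a 1.5-fold higher number from compound 3 to compound 4 (0.19 log units; within the scatter), a slightly higher number. The estimate for compound 4 is 70 nM, in a range from 20 nM to 250 nM.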

Compound 4, half-maximal inhibitory concentration: 20 nM
The estimate for compound 4 lay 3.5-fold (0.54 log units) above the measured number; the measured number falls inside the stated range.
By their numbers in this assay, from the lowest: compounds 4 and 2 (each within the scatter of the next); then compounds 3 and 1 (each within the scatter of the next).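

Methylsulfonyl on this aromatic carbon brings the number down in this assay, with a 2.3-fold lower number from compound 3 to compound 4 (0.36 log units; beyond the scatter) and a 2.4-fold lower number from compound 1 to compound 4 (0.38 log units; beyond the scatter), so this position accepts a group with two double bonds outside aromatic rings without loss. Against methyl there is no separation, with a 1.0-fold lower number from compound 2 to compound 4 (0.02 log units; within the scatter), so of the three substituents only ethoxy stays level with hydrogen. Nothing at hand explains why ethoxy and methylsulfonyl part here. On these data alone, whether an amine, a carboxylic acid or a longer chain on this carbon would keep the number this low remains open.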